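Replacing nitro with ethyl in compound 2

A few compounds are considered here, and "the series" means these few. Any claim that something is new, unique, unknown or untested is made for them only; others in the source may bear on it.

Compound 1 `O=[N+]([O-])c1ccc(SCCc2c[nH]cn2)nc1` gives 2.6 mg/kg
Compound 2 `O=[N+]([O-])c1ccc(OCCc2c[nH]cn2)cc1` gives 0.66 mg/kg
Compound 3 `O=[N+]([O-])c1cccc(OCCc2c[nH]cn2)c1` gives 0.9 mg/kg

In a functional assay on the whole organism (brain) with Mus musculus as the target (on this read-out higher numbers stand for an effect only at larger amounts of compound and lower numbers for an effect already at smaller amounts), compound 2 gives 0.66 mg/kg and compound 3 gives 0.9 mg/kg, two values that lie within the scatter of each other. Compound 1 stands at 2.6 mg/kg, a higher number than that of compound 2 and beyond the scatter.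

Compound 4 `CCc1ccc(OCCc2c[nH]cn2)cc1` has not yet been measured. It has ethyl in place of nitro on an aromatic carbon of compound 2 (ethyl in place of nitro on an aromatic carbon). Among the compounds with values here, no measured pair shows this change, and no measured compound carries ethyl, so the expectation is a loose one. The measured nitro compounds run from compound 2 at 0.66 mg/kg to compound 1 at 2.6 mg/kg, and a modest move towards a higher number in this assay is expected, most likely none beyond the scatter. The estimate means a 1.8-fold higher number from compound 2 to compound 4 (0.26 log units; within the scatter) as the expected step. Compound 4 is estimated at 1.2 mg/kg, with an expected range from 0.35 mg/kg to 4 mg/kg.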

Compound 4, dose for half-maximal effect: > 10 mg/kg
Compound 4 ended at the assay's limit (the forecaster's own chance of this, stated with the estimate: 3%); middle value at least 8.3-fold (0.92 log units) away from the limit.
By their numbers in this assay, from the lowest: compounds 2 and 3 (each within the scatter of the next); then compound 1. At a limit, above all of these: compound 4.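

In this assay compound 4 gives > 10 mg/kg, which is a limit of the assay and not a number: the limit of > 10 mg/kg in this assay, at which 1 of the 4 values shown sits.

Within the data shown here, exchanging nitro for ethyl on the aromatic carbon para to a group of 8 heavy atoms brings an at least 15-fold higher number from compound 2 to compound 4 (1.18 log units; beyond the scatter), the first step that can be read. It shows that the group at this position matters greatly on this read-out and that ethyl does not stand in for nitro here.

A single pair cannot tell whether the step reflects the loss of nitro, the arrival of ethyl, or both. Going by these compounds, what an amine, a nitrile, a methoxy group or plain hydrogen would give at this same position remains open, as does how far above the limit compound 4 truly lies.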